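Benzyloxy in Place of Propyl in a Nitrile Series

A few compounds are considered here, and "the series" means these few. Any claim that something is new, unique, unknown or untested is made for them only; others in the source may bear on it.

Compound 1 `CC(C)(C)OC(=O)N[C@@H](CC1CCCCC1)C(=O)NCC#N`: 44 nM
Compound 2 `CCCC[C@H](NC(=O)OC(C)(C)C)C(=O)NCC#N`: 550 nM

In an assay on isolated protein for inhibition of cathepsin S (Homo sapiens) (a lower number here means a stronger inhibitor, a higher number a weaker inhibitor), compound 2 stands with the highest of the two numbers; its nearest neighbour is compound 1, and the step of a 13-fold higher number from compound 1 to compound 2 (1.10 log units; beyond the scatter) shows how far apart they lie. Compound 3 `CC(C)(C)OC(=O)N[C@@H](COCc1ccccc1)C(=O)NCC#N` differs from compound 2 by benzyloxy in place of propyl on a saturated chain carbon, two bonds along the chain from an amide-type nitrogen and a carbonyl carbon. Going by the values given here, only that one step bears on the change, and it was large when a ring group stood at this carbon. The benzyloxy group also brings a ring, so a lower number is expected for compound 3, with a 3.7-fold lower number from compound 2 to compound 3 (0.56 log units; beyond the scatter) as the estimated step. Compound 3 is therefore expected to give about 150 nM, within a range from 40 nM to 600 nM.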

Compound 3, inhibition constant: 2200 nM
Compound 3: middle estimate off by 15-fold (1.17 log units), on the low side; measured number above the stated range.
By their numbers in this assay, from the lowest: compound 1; then compound 2; then compound 3.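

In this assay a ring in the group on this saturated chain carbon does not by itself give a lower number: benzyloxy, with its six-membered aromatic ring, gives a higher number than propyl (a 4.0-fold higher number from compound 2 to compound 3 (0.60 log units; beyond the scatter)). Its distance from cyclohexyl is larger still (a 50-fold higher number from compound 1 to compound 3 (1.70 log units; beyond the scatter)), so among these compounds a ring helps only in compound 1, and compound 3 goes against any rule that rings help. No measurement shown here accounts for this difference between the two ring groups. The compounds shown leave open how benzyl, which lacks the oxygen of benzyloxy, or a longer chain would stand at this carbon.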